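This account rests on a few compounds, and the source may have more. Where it says the series, first, only, none or still open, it means among the compounds named here.

Compound 3, with the structure `Cc1ccc2cc(CN(Cc3ccc(C(C)(C)C)cc3)C3CCCC3)c(=O)[nH]c2c1`, is the starting point here. In a toxicity assay on MDCK cells (Canis lupus familiaris) for cytotoxicity, read by crystal violet staining, with a stated time of 48 h (on this read-out lower numbers stand for higher toxicity in this test and higher numbers for lower toxicity in this test), compound 3 gives > 10000 nM, which is a limit of the test and not a number. Two other compounds share its core. Compound 1, with the structure `Cc1ccc2cc(CN(Cc3ccc(F)cc3)Cc3ccc(C(C)(C)C)cc3)c(=O)[nH]c2c1`, gives in this assay > 33000 nM, also a limit. Compound 2, with the structure `Cc1ccc2cc(CN(Cc3ccc(C(C)(C)C)cc3)Cc3cc(F)cc(F)c3)c(=O)[nH]c2c1`, gives in this assay > 33000 nM, again a limit. So where compound 3 stands can only be said as the limit of > 10000 nM in this assay, at which 1 of the 3 values shown sits, while the other two values sit at the limit of > 33000 nM in this assay, at which 2 of the 3 values shown sit. The steps between these three compounds cannot be read: a step that the two limits leave unreadable from compound 1 to compound 2, a step that the two limits leave unreadable from compound 1 to compound 3 and a step that the two limits leave unreadable from compound 2 to compound 3. None of them is a measured size.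

Compound 4, with the structure `Cc1ccc2cc(CN(Cc3ccc(C(C)(C)C)cc3)CC3CCCCC3)c(=O)[nH]c2c1`, differs from compound 3 in one place: cyclohexylmethyl in place of cyclopentyl on an amine nitrogen. Going by the values given here, no measured step speaks to this change, and the three values shown are all limits with no readable difference among them. The expectation therefore rests only on that: compound 4 is expected to give in this assay a limit once more, so the step that the limit leaves unreadable from compound 3 to compound 4 is estimated as none beyond the scatter. In this assay compound 4 is estimated at 33000 nM, within a range from 10000 nM to 100000 nM.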

Compound 4, half-maximal cytotoxic concentration: > 10000 nM
Compound 4: only a limit was reported; the forecaster's own chance of this, stated with the estimate: 85%; the middle value is on the limit's open side.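

In this assay compound 4 gives > 10000 nM, which is a limit of the test and not a number. Going by these compounds alone, the steps from compound 4 to compound 1, compound 2 and compound 3 cannot be read, and no new step emerges. The compounds shown leave open whether the groups on the amine nitrogen change the half-maximal cytotoxic concentration at all.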